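Notes on the chain substituent in compound 3 and compound 4

The source may report more compounds than this note shows. Statements on the series, on what has been measured and on what is new or still open speak of the compounds shown alone.

Of the compounds shown here, three have been measured in an ADME assay on HEK-293T cells (Homo sapiens) for inhibition, read by MTT assay, with a stated time of 48 h; a lower number here means a stronger inhibitor, a higher number a weaker inhibitor. Compound 1 `COc1cc(-c2nc3cc(/C=C4\SC(=O)N(CC(=O)N5CCCCC5)C4=O)ccc3[nH]2)cc(OC)c1OC` gives 21500 nM, compound 2 `COc1cc(-c2nc3cc(/C=C4\SC(=O)N(CC(=O)N5CCCC5)C4=O)ccc3[nH]2)cc(OC)c1OC` gives 12700 nM, and compound 3 `COc1cc(-c2nc3cc(/C=C4\SC(=O)N(Cc5ccccc5)C4=O)ccc3[nH]2)cc(OC)c1OC` gives 8210 nM. Compound 3 sits at the low end of the three numbers: the step of a 2.6-fold lower number from compound 1 to compound 3 (0.42 log units; beyond the scatter) is beyond the scatter, whereas a 1.5-fold lower number from compound 2 to compound 3 (0.19 log units; within the scatter) and a 1.7-fold lower number from compound 1 to compound 2 (0.23 log units; within the scatter) are within it.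

Compound 4 `COc1cc(CN2C(=O)S/C(=C\c3ccc4[nH]c(-c5cc(OC)c(OC)c(OC)c5)nc4c3)C2=O)cc(OC)c1OC` differs from compound 3 only in one place: 3,4,5-trimethoxyphenyl in place of phenyl on a saturated chain carbon bound to an amide-type nitrogen in a ring. The measured steps that bear on this position are the two leading to compound 3, in which an amide-linked saturated ring gave way to a phenyl; both were small. Among the compounds with values here, no measured pair shows what substituents on that phenyl do, so the effect of the three methoxy groups is not covered by the data.

Given the small size of the changes seen at this position, the expected step of a 1.0-fold lower number from compound 3 to compound 4 (0.01 log units; within the scatter) is none beyond the scatter, with a wide range to allow for the untested substitution. Compound 4 is therefore estimated at 8000 nM in this assay, between 2500 nM and 25000 nM.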

Compound 4, half-maximal inhibitory concentration: 16600 nM
Compound 4: middle estimate off by 2.1-fold (0.32 log units), on the low side; low and high end bracket the measured number.
By their numbers in this assay, from the lowest: compounds 3, 2, 4 and 1 (each within the scatter of the next, the first and the last beyond it).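

In this assay, within the data shown here, substitution on the phenyl itself can now be read for the first time: a 2.0-fold higher number from compound 3 to compound 4 (0.31 log units; beyond the scatter) is modest but beyond the scatter, so this position responds to a change on the ring and not only to replacing the amide-linked saturated rings with a phenyl. Compound 4 cannot be separated from those amide-linked compounds, since both a 1.3-fold higher number from compound 2 to compound 4 (0.12 log units; within the scatter) and a 1.3-fold lower number from compound 1 to compound 4 (0.11 log units; within the scatter) are within the scatter; the step beyond the scatter that separates compound 1 from compound 3 therefore does not carry over to compound 4, and a phenyl ring at this place does not alone set the number. No measurement available here explains the step from the unsubstituted phenyl to 3,4,5-trimethoxyphenyl.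

Only these two aromatic groups can be compared, which leaves open whether a phenyl with fewer methoxy groups would lie with compound 3 or with compound 4. Also open, from the compounds shown here alone, is how a phenyl bearing a fluorine, an amine or a carboxylic acid, or a longer chain between the ring nitrogen and the phenyl, would read in this assay.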